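Swapping a Urea for an Amide on a Shared Core

The source may hold more compounds than are shown below. What is called first, only, known or untested is meant among the compounds shown, and "the series" means these compounds.

Measured so far:
Compound 1 `O=C(Nc1cccc(-n2cc(-c3ccncc3)c(-c3cc(O)cc(Cl)c3)n2)c1)Nc1ccc(Cl)c(C(F)(F)F)c1`: in a functional assay on BT-549 cells (Homo sapiens) for inhibition, read by sulforhodamine B assay, with a stated time of 48 h, tested at 0.01 uM (on this read-out lower numbers stand for a stronger effect and higher numbers for a weaker effect at the one concentration tested), compound 1 gives 102%.
Compound 2 `COc1cc(Cl)cc(-c2nn(-c3cccc(NC(=O)Nc4ccc(Cl)c(C(F)(F)F)c4)c3)cc2-c2ccncc2)c1`: in this assay compound 2 gives 92%.

Both numbers sit close to the level that means the cells were barely touched at the single concentration used. Among the measured compounds shown here, compound 2 has the lowest of the two numbers, but the only step so far, a number 10 percentage points lower from compound 1 to compound 2 (within the scatter), lies within the scatter, so the two compounds cannot be told apart on this read-out.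

Compound 3, `COc1cc(Cl)cc(-c2nn(-c3cccc(NC(=O)c4cccc(C(F)(F)F)c4)c3)cc2-c2ccncc2)c1`, is not yet measured. It differs from compound 2 in one place: 3-(trifluoromethyl)phenyl in place of (4-chloro-3-(trifluoromethyl)phenyl)amino on a carbonyl carbon. That is, a urea becomes a simple amide and the ring-bound chlorine on that end is gone.

For the measured compounds named here, no measured step touches this part of the molecule; the one step known concerns the oxygen on the other aromatic ring. With both measured compounds near the no-effect level, the expected step of a number 4 percentage points higher from compound 2 to compound 3 (within the scatter) is none beyond the scatter. Compound 3 is therefore estimated at 96%, within 78% to 112%.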

Compound 3, a percentage reported as activity, at one concentration (the size of the read-out at that concentration, not a potency): 108%
The estimate for compound 3 lay 12 percentage points below the measured number; measured number inside the range.
By their numbers in this assay, from the lowest: compounds 2, 1 and 3 (each within the scatter of the next, the first and the last beyond it).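

Among the compounds shown here, this is the first change at the carbonyl end of the molecule, and in this assay putting 3-(trifluoromethyl)phenyl in place of (4-chloro-3-(trifluoromethyl)phenyl)amino gives a number 16 percentage points higher from compound 2 to compound 3 (beyond the scatter), which points toward a weaker effect at the one concentration tested. Unlike the earlier change on the oxygen of the other aromatic ring, this one can be told apart on the read-out, so this position responds to a change even though the step is small and the cells remain close to untouched. The swap alters more than one thing at once, since the group that leaves carries a chlorine and a hydrogen-bond donor and the group that enters carries neither, and no outside data indicate which of these differences accounts for the step.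

The compounds shown leave open whether the chlorine or the urea nitrogen matters, and an amide carrying 4-chloro-3-(trifluoromethyl)phenyl on the carbonyl carbon would separate the two. They also leave open what an amine or a carboxylic acid on that ring would do in this assay.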